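The source may report more compounds than this note shows. Statements on the series, on what has been measured and on what is new or still open speak of the compounds shown alone.

Measured compounds:
compound 1 `C=C1C(=O)O[C@@H]2[C@H]3O[C@]3(C)CC/C=C(\C)[C@@H](OC(=O)C(C)(O)CC)C[C@@H]12`: 11.7 ug/mL
compound 2 `C=C1C(=O)O[C@@H]2[C@H]3O[C@]3(C)CC/C=C(\C)[C@@H](OC(=O)CC(C)(C)O)C[C@@H]12`: 17.5 ug/mL

In a functional assay on HT-29 cells (Homo sapiens) for cytotoxicity, read by MTT assay, with a stated time of 48 h (a lower number here means a stronger inhibitor, a higher number a weaker inhibitor), compound 2 gives 17.5 ug/mL, and compound 1 gives 11.7 ug/mL; the two numbers sit within the scatter of each other, so no ranking between them is claimed. For the measured compounds named here, the single measured step is a 1.5-fold higher number from compound 1 to compound 2 (0.17 log units; within the scatter), a rearrangement of the side chain on the carbonyl carbon that left the cytotoxicity essentially unchanged.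

Compound 3 `C=C1C(=O)O[C@@H]2[C@H]3O[C@]3(C)CC/C=C(\C)[C@@H](OC(=O)C(C)C(C)O)C[C@@H]12` is a further isomer of the same side chain: 2-hydroxy-1-methylpropyl in place of 2-hydroxy-2-methylpropyl on a carbonyl carbon. Going by the values given here, the one comparable step, a 1.5-fold higher number from compound 1 to compound 2 (0.17 log units; within the scatter), bears directly on it, since it too swapped one hydroxylated five-atom chain for another at the same carbonyl carbon and stayed within the scatter. The change from compound 2 to compound 3 is therefore expected to give no step beyond the scatter, a 1.3-fold lower number from compound 2 to compound 3 (0.10 log units; within the scatter). Compound 3 is estimated at 14 ug/mL, with a range from 7 ug/mL to 28 ug/mL.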

Compound 3, half-maximal inhibitory concentration: 11.7 ug/mL
Beside the measured number, compound 3's estimate is 1.2-fold (0.08 log units) above it, and the stated range covers the measured number.
By their numbers in this assay, from the lowest: compounds 1, 3 and 2 (each within the scatter of the next).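

In this assay, 2-hydroxy-1-methylpropyl in place of 2-hydroxy-2-methylpropyl on the carbonyl carbon gives a 1.5-fold lower number from compound 2 to compound 3 (0.17 log units; within the scatter), and in place of 1-hydroxy-1-methylpropyl it gives no change at the digits printed from compound 1 to compound 3 (within the scatter). The finding of no readable effect no longer rests on a single pair: across these three isomeric chains, moving the hydroxyl and the methyl branch produces no step beyond the scatter at this position. No supporting data explain this result.

All three compounds carry chains with the same atoms, so they leave open whether this carbonyl carbon responds to a change in the kind of group, such as an amine or a carboxylic acid in place of the hydroxyl, or to a longer chain. From the compounds shown here alone, whether any change at this position gives a step beyond the scatter in this assay also remains open.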